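A 1H-benzimidazol-2-yl Exchange Among Limits

The source may report more compounds than this note shows. Statements on the series, on what has been measured and on what is new or still open speak of the compounds shown alone.

In an ADME assay on Raji cells (Homo sapiens) for cytotoxicity, with a stated time of 72 h (on this read-out higher numbers stand for an effect only at larger amounts of compound and lower numbers for an effect already at smaller amounts), compound 3 `O=C(Nc1cccc(-c2nc3ccccc3o2)c1)c1cc([N+](=O)[O-])ccc1Cl` reports > 25000 nM as a limit and not as a number. Compound 1 `O=C(Nc1cccc(-c2nc3ccccc3s2)c1)c1cc([N+](=O)[O-])ccc1Cl` reports > 27000 nM in the same way, and this too is a limit. Compound 2 `O=C(Nc1cccc(-c2ccccc2)c1)c1cc([N+](=O)[O-])ccc1Cl` reports > 27000 nM and is likewise held at a limit. Compound 3 therefore has no number of its own, and neither of the other two compounds offers one for comparison.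

The step to compound 4 `O=C(Nc1cccc(-c2nc3ccccc3[nH]2)c1)c1cc([N+](=O)[O-])ccc1Cl` puts 1H-benzimidazol-2-yl in place of 1,3-benzoxazol-2-yl on an aromatic carbon. Three measured exchanges at this same place bear on it. They are a step that the two limits leave unreadable from compound 1 to compound 3 and a step that the two limits leave unreadable from compound 2 to compound 3 and also a step that the two limits leave unreadable from compound 1 to compound 2 in the same read-out. None of them has a readable size, and none of the three compounds left the limit when the group changed. They give no direction for the new exchange, so no change beyond the usual scatter is expected in this assay, and another limit is the likeliest report. The expected step is a number no higher from compound 3 to compound 4 (the limit leaves the size open) on this estimate. For compound 4 the estimated value is 25000 nM with an expected range from 12000 nM to 32000 nM in this read-out.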

Compound 4, half-maximal effective concentration: 20700 nM
Compound 4: the middle estimate sits 1.2-fold (0.08 log units) above what was measured; measured number inside the range.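

Compound 4 is the only one of the four compounds with a number of its own in this assay, so 1H-benzimidazol-2-yl on this aromatic carbon, meta to a large group, is the one group shown that gives a readable value. Read against the three limits, the steps are an at least 1.2-fold lower number from compound 3 to compound 4 (0.08 log units; that floor lies within the scatter) and an at least 1.3-fold lower number from compound 2 to compound 4 (0.11 log units; that floor lies within the scatter) and an at least 1.3-fold lower number from compound 1 to compound 4 (0.11 log units; that floor lies within the scatter) and so they give only floors, while the steps among compounds 1, 2 and 3 cannot be read. The 1H-benzimidazol-2-yl group carries a hydrogen-bond donor that 1,3-benzoxazol-2-yl lacks, but nothing shown ties the number to that donor, and compound 3 remains a limit: the limit of > 25000 nM in this assay, at which 1 of the 4 values shown sits.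

Going by these compounds, how large the true gap is between compound 4 and the other three compounds stays open, as does whether it exceeds the usual scatter. Also open, on these data alone, is what a methyl group on the ring nitrogen of 1H-benzimidazol-2-yl, or a simple amine on this aromatic carbon in its place, would report in this assay.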